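Butylamino analogue of the chloro compound: expected dose

The source may hold more compounds than are shown below. What is called first, only, known or untested is meant among the compounds shown, and "the series" means these compounds.

The four compounds share one core and are compared in a functional assay on the whole organism for inhibition, with Mus musculus as the target; a higher number here means that more compound is needed for the effect, a lower number that less compound is needed. Compound 1 `CCNCC(=O)Nc1cccc2c1CN(C)CC2c1ccccc1` gives 47 mg/kg in this assay. Compound 2 `CCCCNCC(=O)Nc1cccc2c1CN(C)CC2c1ccccc1` carries against compound 1 the change (ethyl in place of hydrogen on a saturated chain carbon, two bonds along the chain from an amine nitrogen); in this assay compound 2 gives 32 mg/kg, a step of a 1.5-fold lower number from compound 1 to compound 2 (0.17 log units; within the scatter). Compound 3 `CCNCC(=O)Nc1cccc2c1CN(C)CC2c1ccc(Cl)cc1` differs from compound 1 by chloro in place of hydrogen on an aromatic carbon; in this assay compound 3 gives 24 mg/kg, a step of a 2.0-fold lower number from compound 1 to compound 3 (0.29 log units; within the scatter). All three numbers lie within the usual scatter of one another, so no order among them is claimed.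

Compound 4 `CCCCNCC(=O)Nc1cccc2c1CN(C)CC2c1ccc(Cl)cc1` is not yet measured. It differs from compound 3 by ethyl in place of hydrogen on a saturated chain carbon, two bonds along the chain from an amine nitrogen, the same change made twice in all in this set, on a place described in identical words. The two cores on which this change is made differ by chloro in place of hydrogen on an aromatic carbon. Among the compounds with values here, the expected step is a 1.5-fold lower number from compound 3 to compound 4 (0.18 log units; within the scatter), resting on the size of a 1.5-fold lower number from compound 1 to compound 2 (0.17 log units; within the scatter) because a 1.5-fold lower number from compound 1 to compound 2 (0.17 log units; within the scatter) is the only measured instance of this change. For compound 4 the estimate in this assay is 16 mg/kg, with 8 mg/kg to 35 mg/kg as the range.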

Compound 4, dose for half-maximal effect: 13.5 mg/kg
The estimate for compound 4 lay 1.2-fold (0.07 log units) above the measured number, and the stated range covers the measured number.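

In this assay, ethylamino to butylamino on the chloro core gives a 1.8-fold lower number from compound 3 to compound 4 (0.25 log units; within the scatter), a step of the same size as on the core without chloro: the same change on two cores in this assay, a 1.5-fold lower number (0.17 log units; within the scatter) from compound 1 to compound 2 and a 1.8-fold lower number (0.25 log units; within the scatter) from compound 3 to compound 4, 1.2-fold (0.08 log units) apart, within the scatter of two such steps. Chloro in place of hydrogen on an aromatic carbon gives a 2.4-fold lower number from compound 2 to compound 4 (0.37 log units; beyond the scatter) on the butylamino core, which is beyond the scatter but only modestly, and its size also agrees with that of the same change on the ethylamino core: the same change on two cores in this assay, a 2.0-fold lower number (0.29 log units; within the scatter) from compound 1 to compound 3 and a 2.4-fold lower number (0.37 log units; beyond the scatter) from compound 2 to compound 4, 1.2-fold (0.08 log units) apart, within the scatter of two such steps. Each change can thus be carried between these two cores with no detectable difference in step size, but this rests on one pair of steps per change and does not show that the same would hold on any other core or in any other assay.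

Still open, going by these compounds, is how a longer chain such as hexylamino, or a cyclic amine such as piperidine, would behave in place of butylamino. Also open, on these data alone, is whether fluoro or methoxy in place of chloro would give a step of similar size.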